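This account rests on a few compounds, and the source may have more. Where it says the series, first, only, none or still open, it means among the compounds named here.

In a functional assay on PC-3 cells (Homo sapiens) for cytotoxicity (on this read-out lower numbers stand for stronger inhibition and higher numbers for weaker inhibition), compound 1 `O=[N+]([O-])c1ccc(/C=N/c2nnc[nH]2)cc1` gives > 30000 nM as a limit and not as a number. Compound 2 `CSc1ccc(/C=N/c2nnc[nH]2)cc1` gives > 30000 nM which is likewise a limit. Among the compounds with values here, the series so far therefore comes down to the limit of > 30000 nM in this assay, at which 2 of the 2 values shown sit, and compound 2 has no numerical position in it.

Compound 3 `CN(C)c1ccc(/C=N/c2nnc[nH]2)cc1` differs from compound 2 by dimethylamino in place of methylsulfanyl on an aromatic carbon and keeps the rest of the core. Within the data shown here, the only measured step bearing on this change is a step that the two limits leave unreadable from compound 1 to compound 2 and it offers no size to carry over. No shift beyond the scatter is therefore expected in this assay in either direction. The expected step is a number no higher from compound 2 to compound 3 (the limit leaves the size open) as an estimate only. For compound 3 the estimated value is 30000 nM with an expected range from 10000 nM to 100000 nM and another limit is the likeliest report.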

Compound 3, half-maximal inhibitory concentration: > 30000 nM
Compound 3 ended at the assay's limit; the forecaster's own chance of this, stated with the estimate: 75%; the middle value sits exactly at the limit.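

No step can be read among compound 1, compound 2 and compound 3 in this assay, because all three values are limits and not numbers: the limit of > 30000 nM in this assay, at which 3 of the 3 values shown sit. The compounds shown leave open whether any other group on the shared core would give a number instead of a limit.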